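The compounds below may be only part of what the source reports. "The series", "measured", "known", "first", "only" and "open" are said of these compounds alone.

Measured so far in a functional assay on MCF7 cells (Homo sapiens) for antiproliferative activity, read by MTT assay, with a stated time of 72 h; a lower number here means a stronger inhibitor, a higher number a weaker inhibitor:
compound 1 `CC/C=C/C(=O)Nc1cc2c(N3CCCc4ccccc43)ncnc2cc1OC` gives 2870 nM
compound 2 `CCC/C=C/C(=O)Nc1cc2c(N3CCCc4ccccc43)ncnc2cc1OC` gives 1210 nM
compound 3 `COc1cc2ncnc(N3CCCc4ccccc43)c2cc1NC(=O)/C=C/CN(C)C` gives 1770 nM

Compound 3 stands second of the three numbers, and neither of its gaps to the other two clears the scatter: a 1.6-fold lower number from compound 1 to compound 3 (0.21 log units; within the scatter) and a 1.5-fold higher number from compound 2 to compound 3 (0.17 log units; within the scatter). For the measured compounds named here, the only step in the set that goes beyond the scatter is a 2.4-fold lower number from compound 1 to compound 2 (0.38 log units; beyond the scatter), which sits at a different place on the chain and does not touch the amine.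

Compound 4 `COc1cc2ncnc(N3CCCc4ccccc43)c2cc1NC(=O)/C=C/CN1CCCC1` differs from compound 3 by pyrrolidin-1-yl in place of dimethylamino on a saturated chain carbon bound to a double-bonded chain carbon. Going by the values given here, no measured step exchanges one amine for another at this position, so the change has no direct precedent here. The two steps into compound 3 replace a methyl or an ethyl with the dimethylamino group at the same chain carbon and stay within the scatter, which suggests this carbon tolerates variation without large movement in this assay. The step that did register, from compound 1 to compound 2, added bulk on the chain and gave a lower number, a loose hint that the ring could move in the same direction.

Compound 4 is therefore expected to show no step beyond the scatter, with a slight lean toward a lower number: a 1.3-fold lower number from compound 3 to compound 4 (0.10 log units; within the scatter). The estimate for compound 4 is 1400 nM, with a range from 500 nM to 4000 nM.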

Compound 4, half-maximal inhibitory concentration: 3190 nM
For compound 4 the middle estimate is 2.3-fold (0.36 log units) below the measured one; the range from low to high includes it.
By their numbers in this assay, from the lowest: compounds 2, 3, 1 and 4 (each within the scatter of the next, the first and the last beyond it).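

Working notes on the series: in this assay the first exchange of one amine for another on the saturated chain carbon bound to a double-bonded chain carbon, pyrrolidin-1-yl in place of dimethylamino, gives a 1.8-fold higher number from compound 3 to compound 4 (0.26 log units; within the scatter), so the two amines cannot be told apart here. Set against the open chains, the ring gives a 2.6-fold higher number from compound 2 to compound 4 (0.42 log units; beyond the scatter) and a 1.1-fold higher number from compound 1 to compound 4 (0.05 log units; within the scatter), which places the ethyl of compound 2 apart from the pyrrolidin-1-yl of compound 4, while the methyl of compound 1 cannot be separated from that ring; a larger group at this carbon therefore does not simply continue a 2.4-fold lower number from compound 1 to compound 2 (0.38 log units; beyond the scatter), and compound 4 goes against any such trend. Nothing at hand bears on why the numbers fall this way.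

On these data alone, with only dimethylamino and pyrrolidin-1-yl as the amines at this carbon, it remains open whether a piperidine or a morpholine would stay within the scatter of these two. As far as these compounds go, it also remains open whether a longer chain such as propyl would extend the step from methyl to ethyl or reverse it.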